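Notes on an aryl swap on the fused five-membered ring

The source may report more compounds than this note shows. Statements on the series, on what has been measured and on what is new or still open speak of the compounds shown alone.

compound 1 `COc1cc(-c2ccnc3cc(-c4ccc5c(ccn5C)c4)nn23)cc(OC)c1OC`: 15 nM
compound 2 `COc1cc(-c2ccnc3cc(-c4cn(C(=O)OC(C)(C)C)c5ccccc45)nn23)cc(OC)c1OC`: 2070 nM

Among the measured compounds shown here, in a functional assay on A549 cells (Homo sapiens) for inhibition, read by CCK-8 assay, with a stated time of 48 h (a lower number here means a stronger inhibitor, a higher number a weaker inhibitor), compound 1 gives 15 nM, the lowest of the two numbers measured so far. For the measured compounds named here, the nearest is compound 2, which in this assay gives 2070 nM, a gap beyond the usual scatter; the two compounds differ only in the substituent on the indole nitrogen, and no computed step is available for that pair.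

Compound 3 `COc1ccc(-c2cc3nccc(-c4cc(OC)c(OC)c(OC)c4)n3n2)cc1F` keeps the shared core of compound 1 and changes one place: 3-fluoro-4-methoxyphenyl in place of 1-methyl-1H-indol-5-yl on an aromatic carbon. Going by the values given here, no measured step covers this kind of change, and compound 2 varies a different part of the molecule, so it gives no direct guide. A smaller group taking the place of the bicyclic one is expected to cost some potency, with the step from compound 1 to compound 3 estimated at a 4.0-fold higher number from compound 1 to compound 3 (0.60 log units; beyond the scatter) in this assay, likely near the edge of the scatter. Compound 3 is expected to give 60 nM, with a plausible range of 12 nM to 400 nM.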

Compound 3, half-maximal inhibitory concentration: 545 nM
Beside the measured number, compound 3's estimate is 9.1-fold (0.96 log units) below it; the whole stated range lies below it.
By their numbers in this assay, from the lowest: compound 1; then compound 3; then compound 2.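

In this assay, this aromatic carbon of the five-membered aromatic ring with 2 nitrogen proves strongly sensitive to the aryl group it carries: 3-fluoro-4-methoxyphenyl in place of 1-methyl-1H-indol-5-yl gives a 36-fold higher number from compound 1 to compound 3 (1.56 log units; beyond the scatter), a large step and the first one read at this place. Among the compounds shown here, the two groups match in hydrogen-bond donors and acceptors and carry no net charge, so those counts do not separate them, while the five-membered aromatic ring of the leaving group has no counterpart in the entering one. Nothing measured here explains the size of the step.

The compounds shown do not separate the contributions of the fluorine, the methoxy group and the lost five-membered ring. Going by these compounds, how an aminomethyl or carboxylic acid group on the aryl ring would read in this assay also remains open.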